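Adding a Third Methoxy Group to an Already Dimethoxylated Ring

This account rests on a few compounds, and the source may have more. Where it says the series, first, only, none or still open, it means among the compounds named here.

Compound 1 `Cc1ncc([N+](=O)[O-])n1CCSc1nnc(-c2ccccc2O)o1` and compound 2 `COc1ccc(-c2nnc(SCCn3c([N+](=O)[O-])cnc3C)o2)c(O)c1` differ by a single change, (methoxy in place of hydrogen on an aromatic carbon). In a functional assay on MCF7 cells (Homo sapiens) for cytotoxicity, read by MTT assay, with a stated time of 48 h (a lower number here means a stronger inhibitor, a higher number a weaker inhibitor), compound 1 gives 28300 nM, and compound 2 gives 21800 nM, so that a 1.3-fold lower number from compound 1 to compound 2 (0.11 log units; within the scatter). Compound 3 `COc1cc(OC)cc(-c2nnc(SCCn3c([N+](=O)[O-])cnc3C)o2)c1` gives 12800 nM in this assay; the difference between the cores of compound 1 and compound 3 is not broken down here. Compound 4 `COc1cc(-c2nnc(SCCn3c([N+](=O)[O-])cnc3C)o2)cc(OC)c1OC` carries methoxy in place of hydrogen on an aromatic carbon. This is the same kind of change as that from compound 1 to compound 2, though the place now lies ortho to two methoxy groups rather than meta to a hydroxy group. In this assay the step is expected to be small, a 1.2-fold lower number from compound 3 to compound 4 (0.09 log units; within the scatter), because a 1.3-fold lower number from compound 1 to compound 2 (0.11 log units; within the scatter) stayed within the scatter. Compound 4 is therefore estimated at 10500 nM, between 5000 nM and 24000 nM.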

Compound 4, half-maximal inhibitory concentration: 30600 nM
For compound 4 the middle estimate is 2.9-fold (0.46 log units) below the measured one, and the stated range ends below it.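

Placed on the ring of compound 3, methoxy in place of hydrogen gives a 2.4-fold higher number from compound 3 to compound 4 (0.38 log units; beyond the scatter) in this assay. Set beside the earlier step, the same change does not carry over unchanged between these two cores: the same change on two cores in this assay, a 1.3-fold lower number (0.11 log units; within the scatter) from compound 1 to compound 2 and a 2.4-fold higher number (0.38 log units; beyond the scatter) from compound 3 to compound 4, 3.1-fold (0.49 log units) apart, beyond the scatter of two such steps

This shows that, for these two pairs, the result of the change cannot be read across from one core to the other, but the pairs differ in both core and place, so it does not show which of the two matters, and it gives no rule for the wider series. On these data alone, it remains open whether an amine or a carboxylic acid in that same place on compound 3 would shift the number as methoxy does. As far as these compounds go, whether a longer chain, such as ethoxy, would behave like methoxy there is also open.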